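The source may report more compounds than this note shows. Statements on the series, on what has been measured and on what is new or still open speak of the compounds shown alone.

Measured in a functional assay on U-87MG ATCC cells for cytotoxicity against U-87 MG (Homo sapiens), read by MTT assay, with a stated time of 72 h; a higher number here means a weaker inhibitor, a lower number a stronger inhibitor:
Compound 1 `COc1ncc(-c2ccc3nc(NC(=O)NCC(=O)N4CCCCC4)nn3c2)cc1NS(=O)(=O)c1ccc(F)cc1`: 740 nM
Compound 2 `COc1ncc(-c2ccc3nc(NC(=O)N4CCCC4)nn3c2)cc1NS(=O)(=O)c1ccc(F)cc1`: 1690 nM

Compound 2 has the higher number of the two, at 1690 nM. Compound 3 `COc1ncc(-c2ccc3nc(NC(=O)N(C)C)nn3c2)cc1NS(=O)(=O)c1ccc(F)cc1` carries dimethylamino in place of pyrrolidin-1-yl on a carbonyl carbon. Among the compounds with values here, only one measured step bears on this place, a 2.3-fold higher number from compound 1 to compound 2 (0.36 log units; beyond the scatter), and it involved a much larger substituent. A smaller step is therefore expected in this assay, perhaps slightly upward and probably within the scatter. The estimated step is a 1.2-fold higher number from compound 2 to compound 3 (0.07 log units; within the scatter). For compound 3 the expected value is 2000 nM, with an estimated range of 800 nM to 5000 nM.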

Compound 3, half-maximal inhibitory concentration: 1780 nM
Compound 3: middle estimate off by 1.1-fold (0.05 log units), on the high side; the range from low to high includes it.
By their numbers in this assay, from the lowest: compound 1; then compounds 2 and 3 (each within the scatter of the next).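

Dimethylamino in place of pyrrolidin-1-yl gives a 1.1-fold higher number from compound 2 to compound 3 (0.02 log units; within the scatter) in this assay, so at this place the ring makes no readable difference. The longer (((piperidin-1-yl)carbonyl)methyl)amino group of compound 1 stands apart from dimethylamino too, with a 2.4-fold higher number from compound 1 to compound 3 (0.38 log units; beyond the scatter), so that gap does not depend on the pyrrolidin-1-yl ring of compound 2. Nothing available explains either step. The compounds shown leave open which part of the longer group goes with the lower number of compound 1. A morpholine in place of its piperidine, or a simple methylamino group on the carbonyl carbon, would help to separate those parts.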